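A few compounds are considered here, and "the series" means these few. Any claim that something is new, unique, unknown or untested is made for them only; others in the source may bear on it.

Compound 1 `CN1C[C@H](Nc2nc3cc[nH]c3c(=O)n2C)C[C@H](c2ccccc2)C1` gives the highest number of the three measured compounds in an assay on isolated protein for binding affinity to histone acetyltransferase KAT2B (Homo sapiens), read by fluorescence, tested at 10 uM (a higher number here means that the compound stabilises the target more against heat, a lower number that the compound stabilises the target less), at 6.3 degrees C. Compound 2 `C=CCn1c(N[C@@H]2C[C@H](c3ccccc3)CN(C)C2)nc2cc[nH]c2c1=O` gives 2.2 degrees C in this assay, and compound 3 `CN1C[C@H](Nc2nc3ccn(C)c3c(=O)n2C)C[C@H](c2ccccc2)C1` gives -0.2 degrees C. Both measured steps alter the shared core: a number 4.1 degrees C lower from compound 1 to compound 2 (beyond the scatter) and a number 6.5 degrees C lower from compound 1 to compound 3 (beyond the scatter). Compound 4 `COc1ccc([C@H]2C[C@@H](Nc3nc4cc[nH]c4c(=O)n3C)CN(C)C2)cc1` differs from compound 1 elsewhere, with methoxy in place of hydrogen on an aromatic carbon. For the measured compounds named here, no measured step touches the phenyl, so neither of the two steps bears directly on this change; they show only that the core does not tolerate alteration, while the phenyl remains untested. Compound 4 is therefore expected to move only a little, by a number 0.80 degrees C lower from compound 1 to compound 4 (within the scatter). The estimate for compound 4 is 5.5 degrees C, with a range from 2.5 degrees C to 8.5 degrees C.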

Compound 4, shift of the target's melting temperature: 8 degrees C
Compound 4: middle estimate off by 2.5 degrees C, on the low side; the measured number falls inside the stated range.
By their numbers in this assay, from the lowest: compound 3; then compound 2; then compound 1; then compound 4.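

In this assay, the change from phenyl to 4-methoxyphenyl gives a number 1.7 degrees C higher from compound 1 to compound 4 (beyond the scatter), the only step shown that raises the number. The phenyl therefore accepts a substituent at this place, para to a large group, whereas both steps on the shared core lowered the number. No evidence is available to explain this rise.

From the compounds shown here alone, what a hydroxyl, an ethoxy chain or an amine would do on this same aromatic carbon remains open. So does the effect of methoxy on another carbon of that ring.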